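Replacing one aryl group by another on compound 2

The source may hold more compounds than are shown below. What is called first, only, known or untested is meant among the compounds shown, and "the series" means these compounds.

Compound 1 `CC(C)(C)Cc1csc(N)c1C(=O)c1ccc(Cl)cc1` carries a hydrogen where compound 2 `CC(C)(C)Cc1c(-c2cc(F)ccc2F)sc(N)c1C(=O)c1ccc(Cl)cc1` carries a 2,5-difluorophenyl group. In an assay on CHO cells for displacement of a labelled ligand from adenosine receptor A1 (Homo sapiens), read by scintillation counting, tested at 10 uM (on this read-out lower numbers stand for less inhibition and higher numbers for more inhibition at the one concentration tested (going by the name of the read-out)), compound 1 gives 1%, and compound 2 gives 3%. Among the measured compounds shown here, the only measured step, a number 2 percentage points higher from compound 1 to compound 2 (within the scatter), separates two numbers that cannot be told apart. On these two numbers compound 2 stands first, but only nominally, since its nearest neighbour, compound 1, lies within the scatter of it. Compound 3 `CC(C)(C)Cc1c(-c2ccc(Cl)cc2)sc(N)c1C(=O)c1ccc(Cl)cc1` differs from compound 2 by a single change: 4-chlorophenyl in place of 2,5-difluorophenyl on an aromatic carbon. For the measured compounds named here, no measured step covers the exchange of one aryl group for another; the single step available, from hydrogen to 2,5-difluorophenyl, gave nothing beyond the scatter. With both measured compounds near the floor of the read-out, compound 3 is expected to give 3%, within a range from -6% to 13%. The step this estimate implies, no change at the digits printed from compound 2 to compound 3 (within the scatter), is expected to remain within the scatter.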

Compound 3, a percentage reported as inhibition, at one concentration (the size of the read-out at that concentration, not a potency): 1%
Estimate against measurement, compound 3: 2 percentage points above; low and high end bracket the measured number.
By their numbers in this assay, from the lowest: compounds 1, 3 and 2 (each within the scatter of the next).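

In this assay, the exchange of one aryl group for another on the aromatic carbon next to the ring sulfur gives a number 2 percentage points lower from compound 2 to compound 3 (within the scatter) and so does not separate 4-chlorophenyl from 2,5-difluorophenyl. Against hydrogen at the same place, 4-chlorophenyl gives no change at the digits printed from compound 1 to compound 3 (within the scatter) and thus joins 2,5-difluorophenyl: neither of these two aryl groups can be told apart from hydrogen at this position, and all three numbers stay near the floor of the read-out. Nothing at hand offers an explanation for this flat result.

From the compounds shown here alone, whether a different kind of group at this position, such as an amine, a carboxylic acid or a longer chain, would give a number beyond the scatter of these three stays open. Also open, going by these compounds, is whether these aryl groups would read differently with the neopentyl group or the (4-chlorophenyl)carbonyl group replaced.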